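The source may hold more compounds than are shown below. What is called first, only, known or untested is meant among the compounds shown, and "the series" means these compounds.

Compound 1 `COc1ccc(CN(Cc2ccc(C(C)(C)C)cc2)Cc2cc3cc(C)ccc3[nH]c2=O)cc1` is the starting point of this comparison. In a toxicity assay on MDCK cells (Canis lupus familiaris) for cytotoxicity, read by crystal violet staining, with a stated time of 48 h (a higher number here means that more compound is tolerated, a lower number that less compound is tolerated), compound 1 gives > 10000 nM, which is a limit of the assay rather than a measured number. Compound 2 `Cc1ccc2[nH]c(=O)c(CN(Cc3ccc(C(C)(C)C)cc3)C(C)c3ccc(F)cc3)cc2c1` carries a 1-(4-fluorophenyl)ethyl group on the amine nitrogen in place of the 4-methoxybenzyl group. In this assay compound 2 gives > 33000 nM, again a limit. Compound 3 `Cc1ccc2[nH]c(=O)c(CN(Cc3ccc(C(C)(C)C)cc3)[C@@H](C)c3ccc(F)cc3)cc2c1` has the same atoms and bonds as compound 2; the only difference is the fact that one of compounds 2 and 3 is drawn with a defined configuration and the other without, at the place where they differ. In this assay compound 3 gives > 5000 nM, also a limit. The steps a step that the two limits leave unreadable from compound 1 to compound 2, a step that the two limits leave unreadable from compound 1 to compound 3 and a step that the two limits leave unreadable from compound 2 to compound 3 thus have no readable size. Each end of these steps sits at a limit: the limit of > 10000 nM in this assay, at which 1 of the 3 values shown sits, the limit of > 33000 nM in this assay, at which 1 of the 3 values shown sits, and (the limit of > 5000 nM in this assay, at which 1 of the 3 values shown sits). Compound 4 `COc1ccc(CN(Cc2ccc(C(C)(C)C)cc2)Cc2cc3ccccc3[nH]c2=O)cc1` differs from compound 1 by hydrogen in place of methyl on an aromatic carbon. Going by the values given here, none of the measured steps touches this place, so no measured step bears on it directly; what the three measured compounds share is that each was tolerated up to its limit. The expected step is a step that the limit leaves unreadable from compound 1 to compound 4, no change beyond the scatter. Compound 4 is therefore expected to give 20000 nM in this assay, with a range from 5000 nM to 100000 nM, most likely reported once more as a limit.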

Compound 4, half-maximal cytotoxic concentration: 1800 nM
The estimate for compound 4 lay 11-fold (1.05 log units) above the measured number; measured number outside the range, below it.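

In this assay, going by these compounds alone, the three earlier compounds all stood at limits, so no step among them could be read and nothing yet showed that any part of these structures affects how much compound the cells tolerate. Compound 4 changes that: hydrogen in place of methyl on an aromatic carbon, a loss of just one carbon atom with no ring, hydrogen-bond donor or acceptor involved, gives an at least 5.5-fold lower number from compound 1 to compound 4 (0.74 log units; beyond the scatter), so this position on the shared core does matter in this assay. Nothing shown here explains why the loss of this methyl has such an effect.

On these data alone, compound 1 gives > 10000 nM, which is a limit, so the full size of the step stays open, and this single pair cannot tell whether the methyl itself counts or whether any group at this carbon would do the same. A chlorine or an ethyl group at this place would help to separate those two readings, and the same hydrogen swap on compound 2 would test whether the step holds with 1-(4-fluorophenyl)ethyl on the amine nitrogen.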